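Swapping the hydrazone aryl group toward a hydroxy-methoxyphenyl

The compounds below may be only part of what the source reports. "The series", "measured", "known", "first", "only" and "open" are said of these compounds alone.

Compound 3 `CN(C)CCn1cnnc1-c1cc(Oc2ccc(NC(=O)N/N=C/c3ccc(F)cc3Cl)cc2F)ccn1` gives the lowest of the two numbers in a functional assay on A549 cells (Homo sapiens) for cytotoxicity, read by MTT assay, with a stated time of 72 h (on this read-out lower numbers stand for stronger inhibition and higher numbers for weaker inhibition), at 1120 nM. Compound 1 `CN(C)CCn1cnnc1-c1cc(Oc2ccc(NC(=O)N/N=C/c3ccc(O)c(Br)c3)cc2F)ccn1` sits close, at 1370 nM, the step of a 1.2-fold lower number from compound 1 to compound 3 (0.09 log units; within the scatter). Compound 2 `COc1ccc(/C=N/NC(=O)Nc2ccc(Oc3ccnc(-c4nncn4CCN(C)C)c3)c(F)c2)cc1O` reaches only a limit of this assay, > 100000 nM. Compound 4 `COc1cc(/C=N/NC(=O)Nc2ccc(Oc3ccnc(-c4nncn4CCN(C)C)c3)c(F)c2)ccc1O` differs from compound 3 by 4-hydroxy-3-methoxyphenyl in place of 2-chloro-4-fluorophenyl on a carbon with a double bond to nitrogen. The nearest measured step is an at least 89-fold lower number from compound 2 to compound 3 (1.95 log units; beyond the scatter), where the group leaving compound 2 carried the same hydroxy and methoxy substituents as the group entering compound 4, while the bromo-hydroxy group of compound 1 kept a low number. Compound 4 is therefore expected to show a rise of a 13-fold higher number from compound 3 to compound 4 (1.13 log units; beyond the scatter), landing at an estimated 15000 nM within 2000 nM to 100000 nM.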

Compound 4, half-maximal inhibitory concentration: > 100000 nM
Compound 4 was reported as a limit; the forecaster's own chance of this, stated with the estimate: 30%; at least 6.6-fold (0.82 log units) between middle value and limit.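

Compound 4 gives a limit of the assay rather than a number, the second such result: the limit of > 100000 nM in this assay, at which 2 of the 4 values shown sit. With 4-hydroxy-3-methoxyphenyl in place of 2-chloro-4-fluorophenyl the change is an at least 89-fold higher number from compound 3 to compound 4 (1.95 log units; beyond the scatter), so this group fails as the 3-hydroxy-4-methoxyphenyl group of compound 2 did, and the step between those two limits cannot be read. Methoxy in place of bromo on an aromatic carbon alone gives an at least 72-fold higher number from compound 1 to compound 4 (1.86 log units; beyond the scatter), so the hydroxy group kept in both does not hold the low number by itself. On these data alone, it stays open whether an amine or a trifluoromethyl group in place of the bromo would keep the low number, and how far past the limit compound 2 and compound 4 lie.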